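Ring-nitrogen substituent series: methyl to pyrimidin-2-yl

The source may report more compounds than this note shows. Statements on the series, on what has been measured and on what is new or still open speak of the compounds shown alone.

compound 1 `COc1ccc(N2CCN(C(=S)SCc3ccc(C(=O)Nc4ccccc4N)cc3)CC2)cc1` — 22.9%
compound 2 `CN1CCN(C(=S)SCc2ccc(C(=O)Nc3ccccc3N)cc2)CC1` — 84.4%

Within the data shown here, in a functional assay on MGC-803 cells (Homo sapiens) for antiproliferative activity, read by CCK-8 assay, with a stated time of 72 h, tested at 8 uM (a higher number here means a stronger effect of the compound at the concentration tested, a lower number a weaker effect), compound 2 stands highest of the two numbers so far; the nearest, compound 1, lies far below it. Among the measured compounds shown here, the single measured step is a number 61.5 percentage points higher from compound 1 to compound 2 (beyond the scatter). Compound 3 `Nc1ccccc1NC(=O)c1ccc(CSC(=S)N2CCN(c3ncccn3)CC2)cc1` follows from compound 2 by the change (pyrimidin-2-yl in place of methyl on an amine nitrogen in a ring). The step from compound 1 to compound 2 bears on this: there too an aromatic ring rather than methyl sat on that ring nitrogen and the number was much weaker. A downward step beyond the scatter, a number 39.4 percentage points lower from compound 2 to compound 3 (beyond the scatter), is therefore expected for compound 3. Compound 3 is estimated at 45%, range 20% to 75%.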

Compound 3, a percentage reported as inhibition, at one concentration (the size of the read-out at that concentration, not a potency): 64.8%
Compound 3: middle estimate off by 19.8 percentage points, on the low side; measured number inside the range.
By their numbers in this assay, from the lowest: compound 1; then compound 3; then compound 2.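

An aromatic ring on this ring nitrogen need not bring a large loss: with pyrimidin-2-yl in place of methyl, the series shows a number 19.6 percentage points lower from compound 2 to compound 3 (beyond the scatter), a modest step. The identity of the aromatic ring matters, since pyrimidin-2-yl in place of 4-methoxyphenyl gives a number 41.9 percentage points higher from compound 1 to compound 3 (beyond the scatter), a large step. Nothing available explains the difference between these two aromatic groups. Open, on these data alone, is where plain phenyl or pyridin-2-yl on the same nitrogen would fall relative to these two aromatic groups. Also open, as far as these compounds go, is whether an ethyl group or a longer alkyl chain would stay close to methyl.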